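Trifluoromethyl added to the triazole-linked aryl of compound 2

This account rests on a few compounds, and the source may have more. Where it says the series, first, only, none or still open, it means among the compounds named here.

Measured so far:
compound 1 `Cc1ccc(-c2cn(-c3ccc(CN4CCN(C)CC4)c(C(F)(F)F)c3)nn2)cc1Nc1nccc(-c2cccnc2)n1` 2660 nM
compound 2 `Cc1ccc(-n2cc(-c3ccc(CN4CCN(C)CC4)cc3)nn2)cc1Nc1nccc(-c2cccnc2)n1` 14900 nM

In an ADME assay on HEK-293T cells (Homo sapiens) for inhibition (on this read-out higher numbers stand for lower toxicity in this test and lower numbers for higher toxicity in this test), compound 2 gives the higher of the two numbers, with compound 1 giving a number that is lower by more than the scatter of repeated measurements. Compound 3 `Cc1ccc(-n2cc(-c3ccc(CN4CCN(C)CC4)c(C(F)(F)F)c3)nn2)cc1Nc1nccc(-c2cccnc2)n1` is not yet measured. It differs from compound 2 by trifluoromethyl in place of hydrogen on an aromatic carbon; the group is placed ortho to a (4-methylpiperazin-1-yl)methyl group and meta to a large group. Among the compounds with values here, no single-change step between measured compounds covers this substitution, since compound 1 carries the same trifluoromethyl but on a differently joined core. On the two values shown, compound 3 is expected to move toward the number of compound 1, a step from compound 2 of a 2.5-fold lower number from compound 2 to compound 3 (0.40 log units; beyond the scatter) in this assay. For compound 3 the estimate in this assay is 6000 nM, with a range from 2000 nM to 18000 nM.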

Compound 3, half-maximal cytotoxic concentration: 8180 nM
Estimate against measurement, compound 3: 1.4-fold (0.13 log units) below; low and high end bracket the measured number.
By their numbers in this assay, from the lowest: compound 1; then compounds 3 and 2 (each within the scatter of the next).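

In this assay, within the data shown here, trifluoromethyl in place of hydrogen on the aromatic carbon ortho to a (4-methylpiperazin-1-yl)methyl group gives a 1.8-fold lower number from compound 2 to compound 3 (0.26 log units; within the scatter), the first single-change reading at this position. With the core of compound 2 held fixed, this substitution alone therefore does not produce a step beyond the scatter of repeated measurements. No measurement shown here bears on the cause of this reading.

From the compounds shown here alone, whether a chlorine atom, a nitrile or a methoxy group on this aromatic carbon would give a step beyond the scatter remains open. The compounds shown also include no partner of compound 1 lacking trifluoromethyl, so the same single change on the core of compound 1 cannot be read in this assay.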